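A few compounds are considered here, and "the series" means these few. Any claim that something is new, unique, unknown or untested is made for them only; others in the source may bear on it.

Measured so far in a functional assay on CHO cells for antagonist activity at metabotropic glutamate receptor 7 (Rattus norvegicus), read by FLIPR and calcium flux; on this read-out lower numbers stand for stronger inhibition and higher numbers for weaker inhibition:
- compound 1 `COc1ccc(-c2cc3onc(-c4ccccc4)c3c(=O)n2C)cc1`: 22 nM
- compound 2 `CC(C)Oc1ccc(-c2cc3onc(-c4ccccc4)c3c(=O)n2C)cc1`: > 10000 nM

The value of compound 2 in this assay is a limit, not a number; it sits at the limit of > 10000 nM in this assay, at which 1 of the 2 values shown sits. Among the compounds with values here, compound 1 differs from compound 2 only in the group on the oxygen, and the step of an at least 450-fold higher number from compound 1 to compound 2 (2.65 log units; beyond the scatter) is the one measured step. Within the data shown here, compound 1 therefore stands as the one compound with a measured number here.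

Compound 3 `CCCc1ccc(-c2cc3onc(-c4ccccc4)c3c(=O)n2C)cc1` is not yet measured. It differs from compound 2 by propyl in place of isopropoxy on an aromatic carbon: the isopropoxy group is replaced by a propyl group on an aromatic carbon, para to a large group. Among the measured compounds shown here, only the step from compound 1 to compound 2 bears on this change, and it was large; it shows that the methyl ether of compound 1 and the isopropyl ether of compound 2 are far apart, but it does not tell how a propyl chain without the oxygen will behave. Since compound 2 stands only at a limit, the step of an at least 1.6-fold lower number from compound 2 to compound 3 (0.22 log units; that floor lies within the scatter) is estimated from that limit and carries wide uncertainty. For compound 3 the expected value in this assay is 6000 nM, with a range from 800 nM to 30000 nM.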

Compound 3, half-maximal inhibitory concentration: 150 nM
Estimate against measurement, compound 3: 40-fold (1.60 log units) above; the measured number lies below the stated range.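

In this assay, isopropoxy to propyl on this aromatic carbon, para to a large group, gives an at least 66-fold lower number from compound 2 to compound 3 (1.82 log units; beyond the scatter), so a chain of this size at this position is compatible with a measured inhibition. Compound 2 stands only at a limit, not a number: the limit of > 10000 nM in this assay, at which 1 of the 3 values shown sits. Propyl in place of methoxy gives a 6.8-fold higher number from compound 1 to compound 3 (0.83 log units; beyond the scatter), so a group without an ether oxygen keeps a measured number here, while the methoxy group still gives the lower number of this pair.

The change from isopropoxy to propyl removes the oxygen and the branching together, and the compounds shown do not separate the two; an isopropyl group set directly on the aromatic carbon, or a propoxy group, would bear on that question. Going by these compounds, how a longer chain, an amine or a carboxylic acid on this carbon would read in this assay also stays open, as does whether the pattern seen with these three ethers and alkyl groups extends to any other group at this position.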